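This account rests on a few compounds, and the source may have more. Where it says the series, first, only, none or still open, it means among the compounds named here.

Working notes on the series. All three measured compounds share one core and differ only in the group on the amide-type nitrogen. Compound 1 `Fc1cccc(NC(=S)N/N=C/c2ccc3ccccc3n2)c1` bears a 3-fluorophenyl; in a functional assay on HeLa cells (Homo sapiens) for antiproliferative activity, read by sulforhodamine B assay, with a stated time of 72 h (on this read-out higher numbers stand for weaker inhibition and lower numbers for stronger inhibition), compound 1 gives 70100 nM. Compound 2 `S=C(N/N=C/c1ccc2ccccc2n1)Nc1cccc(Cl)c1` bears a 3-chlorophenyl; in this assay compound 2 gives 52500 nM, the step being a 1.3-fold lower number from compound 1 to compound 2 (0.13 log units; within the scatter). Compound 3 `Cc1ccccc1NC(=S)N/N=C/c1ccc2ccccc2n1` bears a 2-methylphenyl. For compound 3 this assay reports only a limit, > 100000 nM. Compound 3 thus sits at the limit of > 100000 nM in this assay, at which 1 of the 3 values shown sits; the steps into it, an at least 1.4-fold higher number from compound 1 to compound 3 (0.15 log units; that floor lies within the scatter) and an at least 1.9-fold higher number from compound 2 to compound 3 (0.27 log units; that floor lies within the scatter), are floors that stay within the scatter, so compound 3 is not separated from compound 1 or compound 2 on these numbers.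

Compound 4 `Fc1ccccc1NC(=S)N/N=C/c1ccc2ccccc2n1` differs from compound 3 by fluoro in place of methyl on an aromatic carbon. Among the compounds with values here, no measured step exchanges methyl for fluoro. The nearest comparison is the halogen exchange from compound 1 to compound 2, a 1.3-fold lower number from compound 1 to compound 2 (0.13 log units; within the scatter), within scatter, and the two steps into compound 3 give only floors. The change is therefore expected to move compound 4 little beyond the scatter, an at least 1.1-fold lower number from compound 3 to compound 4 (0.04 log units; that floor lies within the scatter), with a real chance that this assay again returns only a limit. Compound 4 is estimated at 90000 nM, between 40000 nM and 200000 nM.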

Compound 4, half-maximal inhibitory concentration: > 100000 nM
Compound 4: only a limit was reported; the forecaster's own chance of this, stated with the estimate: 50%; middle value at least 1.1-fold (0.04 log units) from the limit.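

Compound 4, with fluoro in place of methyl on the aromatic carbon ortho to a large group, also yields only a limit in this assay, > 100000 nM, and the step between compound 3 and compound 4 cannot be read, since both values are limits. Against the two compounds with numbers, the steps are only floors, an at least 1.4-fold higher number from compound 1 to compound 4 (0.15 log units; that floor lies within the scatter) and an at least 1.9-fold higher number from compound 2 to compound 4 (0.27 log units; that floor lies within the scatter), so compound 4 is not separated from compound 1 or compound 2 on these numbers. What the result adds is that the limit is no longer confined to the 2-methylphenyl compound, since 2-fluorophenyl reaches it too, and the two compounds at the limit are the two with a group ortho to a large group, a grouping that these floors do not establish as a real difference: the limit of > 100000 nM in this assay, at which 2 of the 4 values shown sit.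

As far as these compounds go, it remains open how far above the limit compound 3 and compound 4 truly lie, and so whether methyl and fluoro differ at this position at all. From the compounds shown here alone, it is also open whether the position or the group governs the read-out, which a 3-methylphenyl or 2-chlorophenyl would test, and whether an amine or a carboxylic acid on the same aromatic carbon would give a readable number.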